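Removing the ethoxycarbonyl group: expected distribution of compound 3

The source may report more compounds than this note shows. Statements on the series, on what has been measured and on what is new or still open speak of the compounds shown alone.

Measured in an ADME assay on the whole organism (Mus musculus, strain ICR) for pharmacokinetics, read by LC-MS, with a stated time of 24 h, at a dose of 2 mg/kg by the intravenous route; on this read-out higher numbers stand for wider distribution into tissues and lower numbers for narrower distribution:
Compound 1 `CCN1CCN(c2cc(Nc3cc(C)nn3C(=O)C(C)(C)C)nc(N[C@H]3CCN(C(=O)c4ccc(Cl)cc4F)C3)n2)CC1` gives 18.8 L/kg.
Compound 2 `CCOC(=O)n1nc(C)cc1Nc1cc(N2CCN(CC)CC2)nc(N[C@H]2CCN(C(=O)c3ccc(Cl)cc3F)C2)n1` gives 2.8 L/kg.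

Compound 2 stands lowest of the two numbers shown. Its nearest neighbour is compound 1, separated by a 6.7-fold lower number from compound 1 to compound 2 (0.83 log units; beyond the scatter), a step beyond the scatter that goes with ethoxy in place of tert-butyl on a carbonyl carbon. Compound 3 `CCN1CCN(c2cc(Nc3cc(C)[nH]n3)nc(N[C@H]3CCN(C(=O)c4ccc(Cl)cc4F)C3)n2)CC1` has not yet been measured in this assay. It differs from compound 2 in one place: 5-methyl-1H-pyrazol-3-yl in place of 1-(ethoxycarbonyl)-3-methyl-1H-pyrazol-5-yl on a nitrogen on an aromatic ring. The carbonyl-bearing substituent on the ring nitrogen thus departs altogether, leaving a ring hydrogen in its place.

Within the data shown here, only one measured step bears on this change, a 6.7-fold lower number from compound 1 to compound 2 (0.83 log units; beyond the scatter), and it swapped one group on the carbonyl for another rather than removing the carbonyl itself, so it points to the direction only loosely: the two measured compounds sit far apart, and compound 3 carries neither of their carbonyl groups. A moderate rise in this assay is expected, estimated as a 1.8-fold higher number from compound 2 to compound 3 (0.25 log units; within the scatter). Compound 3 is therefore expected to give about 5 L/kg in this assay, within a range from 1.5 L/kg to 15 L/kg.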

Compound 3, volume of distribution at steady state: 11.3 L/kg
Beside the measured number, compound 3's estimate is 2.3-fold (0.35 log units) below it, and the stated range covers the measured number.
By their numbers in this assay, from the lowest: compound 2; then compounds 3 and 1 (each within the scatter of the next).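

In this assay, the step from the 1-(ethoxycarbonyl)-3-methyl-1H-pyrazol-5-yl group to the smaller 5-methyl-1H-pyrazol-3-yl group gives a 4.0-fold higher number from compound 2 to compound 3 (0.61 log units; beyond the scatter), so removing the whole carbonyl-bearing substituent changes the read-out by more than the usual scatter. Removing the tert-butyl version gives a 1.7-fold lower number from compound 1 to compound 3 (0.22 log units; within the scatter), which means compound 1 and compound 3 cannot be told apart on this read-out, and compound 2 is the one that stands apart in this set of three. Among these compounds, the earlier pair showed only that the two carbonyl groups differ, while the new compound shows that the ethoxycarbonyl version departs from the compound with a ring hydrogen and the tert-butyl version does not, though nothing measured here explains this.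

The compounds shown leave open whether this low number belongs to the ethoxy group specifically or would also appear with a methoxy group or a longer alkoxy chain on the same carbonyl. They also do not show where a simple acetyl group or a methyl group on that ring nitrogen would fall.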